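The source may report more compounds than this note shows. Statements on the series, on what has been measured and on what is new or still open speak of the compounds shown alone.

Measured so far:
Compound 1 `COc1ccc(/C=C/c2cc(=O)cco2)cc1` — 377 uM
Compound 2 `COc1ccc(/C=C/c2cc(=O)cco2)cc1OC` — 635 uM
Compound 3 `COc1ccc(/C=C/C2CC=CC(=O)O2)cc1` — 21.6 uM

In a functional assay on 786-0 cells (Homo sapiens) for inhibition, read by sulforhodamine B assay, with a stated time of 48 h (on this read-out higher numbers stand for weaker inhibition of growth and lower numbers for stronger inhibition of growth), compound 3 gives the lowest number of the three, and its gaps to compound 1 and compound 2 are beyond the usual scatter. The difference between the core of compound 3 and the core of compound 1 is not broken down here. Compound 1 and compound 2 differ by methoxy in place of hydrogen on an aromatic carbon, and that change gave a 1.7-fold higher number from compound 1 to compound 2 (0.23 log units; within the scatter). Compound 4 `COc1ccc(/C=C/C2CC=CC(=O)O2)c(OC)c1` is not yet measured in this assay; it differs from compound 3 by methoxy in place of hydrogen on an aromatic carbon. This is the same kind of change, not the same: in compound 2 the methoxy sits ortho to a methoxy group and meta to a group of 9 heavy atoms, in compound 4 ortho to a group of 9 heavy atoms and meta to a methoxy group. A step of about a 1.5-fold higher number from compound 3 to compound 4 (0.17 log units; within the scatter) is expected, because a 1.7-fold higher number from compound 1 to compound 2 (0.23 log units; within the scatter). Compound 4 is therefore estimated at 32 uM, within 12 uM to 85 uM.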

Compound 4, concentration for growth inhibition (reported as GI): 4.1 uM
Compound 4: the middle estimate sits 7.8-fold (0.89 log units) above what was measured, outside the stated range (below it).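

On the core of compound 3, methoxy in place of hydrogen gave a 5.3-fold lower number from compound 3 to compound 4 (0.72 log units; beyond the scatter). This change therefore did not carry over unchanged from one core to the other in this series: the same change on two cores in this assay, a 1.7-fold higher number (0.23 log units; within the scatter) from compound 1 to compound 2 and a 5.3-fold lower number (0.72 log units; beyond the scatter) from compound 3 to compound 4, 8.9-fold (0.95 log units) apart, beyond the scatter of two such steps. Going by these compounds alone, the two steps differ in more than the core, since the methoxy in compound 4 sits ortho to a group of 9 heavy atoms and meta to a methoxy group, a different place from the one it occupies in compound 2, so these two pairs do not show whether the core or the place accounts for the gap.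

Still open, on these data alone, is what methoxy would do in the same place on both cores. Also open, as far as these compounds go, is whether another group in that place, such as an amine or a carboxylic acid, would give a similar step.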